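Positional isomers of the carboxyphenyl ether in the series

This account rests on a few compounds, and the source may have more. Where it says the series, first, only, none or still open, it means among the compounds named here.

Among the measured compounds shown here, compound 2 `Cc1cc(C(=O)O)ccc1OCCCCOc1ccc(C(=O)CC(C)C)c(O)c1C` gives the lowest of the two numbers so far, 192 nM in an assay on HEK293 cells for positive allosteric modulation of metabotropic glutamate receptor 2 (Rattus norvegicus), read by thallium flux, with a stated time of 2.5 min; on this read-out higher numbers stand for an effect only at larger amounts of compound and lower numbers for an effect already at smaller amounts; compound 1 `Cc1c(OCCCCOc2ccccc2C(=O)O)ccc(C(=O)CC(C)C)c1O` gives 415 nM, and the one measured step is a 2.2-fold lower number from compound 1 to compound 2 (0.33 log units; beyond the scatter). Compound 3 `Cc1cc(OCCCCOc2ccc(C(=O)CC(C)C)c(O)c2C)ccc1C(=O)O` differs from compound 2 by 4-carboxy-3-methylphenyl in place of 4-carboxy-2-methylphenyl on an oxygen on a saturated carbon. For the measured compounds named here, that single step exchanged 2-carboxyphenyl for 4-carboxy-2-methylphenyl, so it bears only loosely on shifting the methyl alone; no step isolating the methyl position is available. A step within the scatter is therefore expected for a 1.3-fold higher number from compound 2 to compound 3 (0.11 log units; within the scatter). Compound 3 is estimated at 250 nM, with a range of 100 nM to 650 nM.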

Compound 3, half-maximal effective concentration: 173 nM
Compound 3: the middle estimate sits 1.4-fold (0.16 log units) above what was measured; measured number inside the range.
By their numbers in this assay, from the lowest: compounds 3 and 2 (each within the scatter of the next); then compound 1.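

With the carboxyl group held as in 4-carboxy-2-methylphenyl, the methyl shift to 4-carboxy-3-methylphenyl gives a 1.1-fold lower number from compound 2 to compound 3 (0.05 log units; within the scatter) in this assay, so both methyl placements read alike at this place. The gain over 2-carboxyphenyl persists, with a 2.4-fold lower number from compound 1 to compound 3 (0.38 log units; beyond the scatter), but that step changes the carboxyl and methyl together and cannot separate them. Nothing measured here accounts for either step.

Open: whether the methyl matters at all, as 4-carboxyphenyl would show. Also open, from the compounds shown here alone, is how an amide or tetrazole in place of the carboxylic acid, or a longer chain, would read.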